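Swapping Methyl for Chloro on the Shared Core

A few compounds are considered here, and "the series" means these few. Any claim that something is new, unique, unknown or untested is made for them only; others in the source may bear on it.

Of the compounds shown here, two have been measured. In a functional assay on MDA-MB-435S cells (Homo sapiens) for antiproliferative activity, read by MTT assay, with a stated time of 72 h (on this read-out higher numbers stand for weaker inhibition and lower numbers for stronger inhibition), compound 1 `O=c1c(CSC(=S)N2CCOCC2)coc2cc(Cl)ccc12` gives 600 nM, while compound 2 `Cc1ccc2c(=O)c(CSC(=S)N3CCCC3)coc2c1` gives 1900 nM, the higher of the two numbers, with a gap to compound 1 beyond the scatter. Compound 3 `O=c1c(CSC(=S)N2CCCC2)coc2cc(Cl)ccc12` arises from compound 2 by chloro in place of methyl on an aromatic carbon. No single change of this kind has been measured, and compound 1 differs from compound 3 elsewhere as well, so only a modest step toward a lower number is expected. Compound 3 is expected to give 1000 nM, within 350 nM to 2800 nM. The expected step is a 1.9-fold lower number from compound 2 to compound 3 (0.28 log units; within the scatter).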

Compound 3, half-maximal inhibitory concentration: 6400 nM
Compound 3: the middle estimate sits 6.4-fold (0.81 log units) below what was measured; the whole stated range lies below it.
By their numbers in this assay, from the lowest: compound 1; then compound 2; then compound 3.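

In this assay, chloro in place of methyl on an aromatic carbon, with pyrrolidin-1-yl held on the thiocarbonyl carbon, gives a 3.4-fold higher number from compound 2 to compound 3 (0.53 log units; beyond the scatter) and so moves the number up, not down. Pyrrolidin-1-yl in place of morpholin-4-yl on the thiocarbonyl carbon, with chloro held on the core, gives an 11-fold higher number from compound 1 to compound 3 (1.03 log units; beyond the scatter) in the same direction. Nothing available accounts for either step.

On these data alone, whether chloro and methyl keep this order with morpholin-4-yl on the thiocarbonyl carbon stays open. So does where a fluoro or methoxy group on that aromatic carbon, or a piperidin-1-yl group on the thiocarbonyl carbon, would fall.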